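Moving the chlorine on the lactam-bound phenyl ring

A few compounds are considered here, and "the series" means these few. Any claim that something is new, unique, unknown or untested is made for them only; others in the source may bear on it.

Of the compounds shown here, three sharing a chlorophenyl-oxadiazole motif have been tested in an in vitro functional assay on HEK293-A cells for negative allosteric modulation of metabotropic glutamate receptor 5 (Homo sapiens), read by FLIPR and calcium flux; on this read-out lower numbers stand for stronger inhibition and higher numbers for weaker inhibition. Compound 1 `O=C1CC(c2nc(-c3cccc(Cl)c3)no2)CN1c1ccccc1Cl` gives 680 nM, the lowest of the three numbers. Compound 3 `O=C1COc2ccccc2N1Cc1nc(-c2cccc(Cl)c2)no1` gives 770 nM in this assay, and compound 2 `O=c1sc2ccccc2n1Cc1nc(-c2cccc(Cl)c2)no1` gives 1100 nM; both of these lie within the usual scatter of the number for compound 1, so the three cannot be placed in an order.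

Compound 4 `O=C1CC(c2nc(-c3cccc(Cl)c3)no2)CN1c1ccc(Cl)cc1` has not yet been measured. It differs from compound 1 in one place only: 4-chlorophenyl in place of 2-chlorophenyl on an amide-type nitrogen in a ring. The same atoms are present; only the arrangement on the ring bound to the amide-type nitrogen changes.

Among the measured compounds shown here, no pair of measured compounds shows a step of this kind, so the expectation rests on compound 1 alone. The account expects the step of a 1.8-fold higher number from compound 1 to compound 4 (0.25 log units; within the scatter) to run toward a somewhat higher number, of a size that may or may not pass beyond the scatter. Compound 4 is therefore estimated at 1200 nM, with a range from 350 nM to 4500 nM.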

Compound 4, half-maximal inhibitory concentration: > 10000 nM
Compound 4: only a limit was reported (the forecaster's own chance of this, stated with the estimate: 10%); at least 8.3-fold (0.92 log units) between middle value and limit.
By their numbers in this assay, from the lowest: compounds 1, 3 and 2 (each within the scatter of the next). At a limit, above all of these: compound 4.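

In this assay compound 4 gives > 10000 nM, which is a limit of the assay and not a number. Among the compounds shown here, putting 4-chlorophenyl in place of 2-chlorophenyl on the amide-type nitrogen gives an at least 14-fold higher number from compound 1 to compound 4 (1.16 log units; beyond the scatter), so this position, which no earlier pair of compounds had tested, responds strongly to the arrangement on the ring even though the atoms stay the same. The step therefore has a floor but no measured top: the limit of > 10000 nM in this assay, at which 1 of the 4 values shown sits.

From the compounds shown here alone, it remains open how a plain phenyl group or a methoxyphenyl group on the same nitrogen would compare with 2-chlorophenyl and 4-chlorophenyl. Also open, going by these compounds, is whether moving the chlorine on the other chlorophenyl ring, the one on the oxadiazole, would matter as much.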